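Swapping the amide substituent of a compound without measurable potency

The source may report more compounds than this note shows. Statements on the series, on what has been measured and on what is new or still open speak of the compounds shown alone.

compound 1: `C=CC1=C(C(=O)Nc2ccccc2OC)C(c2ccc(Cl)c(Cl)c2)OC1` — > 100000 nM
compound 2: `C=CC1=C(C(=O)NC2CCCCC2)C(c2ccc(OC)cc2)OC1` — > 100000 nM

Both numbers come from a functional assay on SW480 cells (Homo sapiens) for cytotoxicity, read by MTT assay, with a stated time of 24 h; a higher number here means a weaker inhibitor, a lower number a stronger inhibitor. The value of compound 1 is a limit of the assay, not a number. The value of compound 2 is likewise a limit and not a number. Compound 2 thus stands where every value shown so far stands, namely at the limit of > 100000 nM in this assay, at which 2 of the 2 values shown sit.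

Compound 3 `C=CC1=C(C(=O)Nc2ccccc2OC)C(c2ccc(OC)cc2)OC1` is not yet measured. It differs from compound 2 in one place: 2-methoxyphenyl in place of cyclohexyl on an amide-type nitrogen. Going by the values given here, no measured pair differs in only this place, so the size of this step cannot be read from the data. Compound 1 already carries the same 2-methoxyphenyl on its amide nitrogen and also sits at the limit. On that basis the step from compound 2 to compound 3 is expected to be none beyond the scatter, and a limit is again the likeliest result. Compound 3 is expected at 150000 nM, between 50000 nM and 500000 nM. The expected step is a step that the limit leaves unreadable from compound 2 to compound 3.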

Compound 3, half-maximal inhibitory concentration: > 100000 nM
Compound 3 was reported as a limit (the forecaster's own chance of this, stated with the estimate: 85%); the middle value does not contradict the limit.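

Going by these compounds alone, compound 1, compound 2 and compound 3 all give limits of the assay rather than numbers, so no step between them can be read: the limit of > 100000 nM in this assay, at which 3 of the 3 values shown sit. The compounds shown leave open whether any amide substituent on this core gives a measurable value in this assay.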